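Pyrimidinyloxy Ether Replaces a Benzimidazole Thioether

The source may hold more compounds than are shown below. What is called first, only, known or untested is meant among the compounds shown, and "the series" means these compounds.

Compound 2 `CC(C)[C@H](NC(=O)COc1cccc2ccccc12)C(=O)N[C@@H](CC(=O)O)C(=O)CSc1nc2ccccc2[nH]1` gives in a functional assay on Jurkat cells (Homo sapiens) for inhibition (a lower number here means a stronger inhibitor, a higher number a weaker inhibitor), only a limit of > 200000 nM. Compound 1 `CC(C)[C@H](NC(=O)COc1cccc2ccccc12)C(=O)N[C@@H](CC(=O)O)C(=O)CSc1nc(-c2ccccc2)no1` gives in this assay 102000 nM. Among the measured compounds shown here, the single measured step, an at least 1.9-fold higher number from compound 1 to compound 2 (0.29 log units; that floor lies within the scatter), rests on the limit of > 200000 nM in this assay, at which 1 of the 2 values shown sits, and therefore marks only a floor. Compound 3 `CC(C)[C@H](NC(=O)COc1cccc2ccccc12)C(=O)N[C@@H](CC(=O)O)C(=O)COc1cc(C(F)(F)F)ncn1` has not been measured; it carries (6-(trifluoromethyl)pyrimidin-4-yl)oxy in place of (1H-benzimidazol-2-yl)sulfanyl on a saturated chain carbon bound to a carbonyl carbon. For the measured compounds named here, no measured step covers this kind of change, so the step of an at least 1.3-fold lower number from compound 2 to compound 3 (0.12 log units; that floor lies within the scatter) is estimated with little support and is taken as none beyond the scatter. Compound 3 is expected to give 150000 nM, within 30000 nM to 600000 nM.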

Compound 3, half-maximal inhibitory concentration: > 200000 nM
Compound 3 ended at the assay's limit; the forecaster's own chance of this, stated with the estimate: 45%; middle value at least 1.3-fold (0.12 log units) from the limit.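

In this assay, compound 3 gives > 200000 nM, which is a limit of the assay and not a number. The change from (3-phenyl-1,2,4-oxadiazol-5-yl)sulfanyl to (6-(trifluoromethyl)pyrimidin-4-yl)oxy on this saturated chain carbon gives an at least 1.9-fold higher number from compound 1 to compound 3 (0.29 log units; that floor lies within the scatter), so an oxygen-linked pyrimidine at this position also shows no inhibition stronger than that of compound 1. The step between compound 2 and compound 3 cannot be read, because both values are limits: the limit of > 200000 nM in this assay, at which 2 of the 3 values shown sit.

Going by these compounds, in compound 3 the linking atom and the ring change together, so their separate contributions remain open. A (1H-benzimidazol-2-yl)oxy group at this position would separate them.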